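The compounds below may be only part of what the source reports. "The series", "measured", "known", "first", "only" and "open" are said of these compounds alone.

Compound 1 `COCCNc1nc(C)c(-c2nc3cnccc3s2)c(N[C@@H]2C[C@H](C(C)(C)O)[C@@H](O)[C@H]2O)n1` gives 617 ng.h/mL in an ADME assay on the whole organism (plasma) for pharmacokinetics, with Rattus norvegicus as the target, with a stated time of 6 h, at a dose of 10 mg/kg by the oral route; a lower number here means less compound in the circulation, a higher number more compound in the circulation at the dose given.
Compound 2 `CCC(O)(CC)[C@H]1C[C@@H](Nc2nc(NCC3CC3)nc(C)c2-c2nc3c(C)nccc3s2)[C@H](O)[C@@H]1O` gives 5130 ng.h/mL in this assay.
Compound 3 `Cc1nc(NC2CC2)nc(N[C@@H]2C[C@H](C(C)(C)O)[C@@H](O)[C@H]2O)c1-c1nc2c(C)nccc2s1` gives 27300 ng.h/mL in this assay.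

Compound 3 stands highest of the three in this assay; its gap to compound 2 is beyond the scatter, and its gap to compound 1 is wider still. Compound 4 `COCC1(CNc2nc(C)c(-c3nc4c(C)nccc4s3)c(N[C@@H]3C[C@H](C(C)(C)O)[C@@H](O)[C@H]3O)n2)CC1` differs from compound 3 by a group of 7 heavy atoms (6 carbon, 1 oxygen; one three-membered non-aromatic ring of carbon only) in place of a group of 3 heavy atoms (3 carbon; one three-membered non-aromatic ring of carbon only), on a nitrogen on an aromatic ring. Among the compounds with values here, no measured pair shows this change on its own, so its size and direction cannot be read from the data. With the exchange untested, a downward step of moderate size is expected, though a number within the scatter of compound 3 would not surprise. The estimate means a step of a 3.0-fold lower number from compound 3 to compound 4 (0.48 log units; beyond the scatter). For compound 4 the expected value in this assay is 9000 ng.h/mL, within a range from 2000 ng.h/mL to 30000 ng.h/mL.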

Compound 4, area under the concentration-time curve: 370 ng.h/mL
Compound 4: the middle estimate sits 24-fold (1.39 log units) above what was measured, outside the stated range (below it).
By their numbers in this assay, from the lowest: compounds 4 and 1 (each within the scatter of the next); then compound 2; then compound 3.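

On a nitrogen on an aromatic ring, replacing cyclopropyl with the larger group that keeps a three-membered ring and adds an oxygen gives a 74-fold lower number from compound 3 to compound 4 (1.87 log units; beyond the scatter) in this assay. This is the first change at a single place among these compounds, and it shows that the amount in the circulation can depend strongly on the group held there. Nothing measured here gives a cause for the step.

On these data alone, whether the oxygen or the extra carbons matter more remains open. So does how a longer plain carbon chain or a cyclobutyl group on that nitrogen would compare.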